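The source may report more compounds than this note shows. Statements on the series, on what has been measured and on what is new or still open speak of the compounds shown alone.

Working notes on the series

Compound 1 `N#Cc1ccccc1-c1cc(F)cc(-n2nnc(-c3ccccn3)n2)c1` is taken as the reference point. In an assay for binding affinity to metabotropic glutamate receptor 5 (Rattus norvegicus) (on this read-out higher numbers stand for weaker inhibition and lower numbers for stronger inhibition), compound 1 gives 4 nM. Going by the values given here, the only other compound measured is compound 2 `Cc1ccncc1-c1cc(F)cc(-n2nnc(-c3ccccn3)n2)c1`, which in this assay gives 2 nM; the step of a 2.0-fold lower number from compound 1 to compound 2 (0.30 log units; within the scatter) lies within the scatter. Compound 1 thus carries the upper of the two numbers recorded so far, but since its separation from compound 2 is within the scatter, the two compounds are not distinguished by these data.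

Compound 3 `Nc1ccncc1-c1cc(F)cc(-n2nnc(-c3ccccn3)n2)c1` has not yet been measured. It differs from compound 1 as follows: 4-aminopyridin-3-yl in place of 2-cyanophenyl on an aromatic carbon.

Among the compounds with values here, the one measured step that bears on this change is the step from compound 1 to compound 2, where the same 2-cyanophenyl left and a 4-methylpyridin-3-yl entered; that step, a 2.0-fold lower number from compound 1 to compound 2 (0.30 log units; within the scatter), was within the scatter. Compound 3 carries a 4-aminopyridin-3-yl at the same place, so a step of similar size is expected, in no direction beyond the scatter. The step of a 1.3-fold lower number from compound 1 to compound 3 (0.12 log units; within the scatter) is therefore the expectation. For compound 3 the estimated value in this assay is 3 nM, with a range from 1 nM to 12 nM.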

Compound 3, inhibition constant: 20 nM
The estimate for compound 3 lay 6.7-fold (0.82 log units) below the measured number; the whole stated range lies below it.
By their numbers in this assay, from the lowest: compounds 2 and 1 (each within the scatter of the next); then compound 3.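

The position on the aromatic carbon meta to a fluoro group is not indifferent to what it carries: in this assay the step to a 4-aminopyridin-3-yl is a 5.0-fold higher number from compound 1 to compound 3 (0.70 log units; beyond the scatter) and lies beyond the scatter, whereas the step to a 4-methylpyridin-3-yl, a 2.0-fold lower number from compound 1 to compound 2 (0.30 log units; within the scatter), did not separate the two compounds. Going by these compounds alone, the closer comparison is the single exchange of amino for methyl, which gives a 10-fold higher number from compound 2 to compound 3 (1.00 log units; beyond the scatter) and shows that a pyridin-3-yl at this place does not by itself keep the number low, since one small group on that ring is enough to move it beyond the scatter. Nothing available accounts for this step.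

The compounds shown cannot tell whether the higher number belongs to amino specifically or would also follow from other groups in place of the methyl, such as a hydroxy, a methoxy or a dimethylamino group. They also leave open whether a larger alkyl group such as ethyl would stay level with methyl, and whether the amino step would be of similar size on a 2-cyanophenyl-type ring or only on this pyridine.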